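The compounds below may be only part of what the source reports. "The series", "measured", "known", "first", "only" and "open" are said of these compounds alone.

Measured so far in a functional assay on the whole organism (strain albino) for inhibition, with Rattus norvegicus as the target, read by paw edema, with a stated time of 2 h, at a dose of 0.28 mmol/kg by the oral route; a higher number here means more inhibition at the dose given (going by the name of the read-out), a lower number less inhibition: compound 1 `COc1ccc(-c2nnc(SC/C(=N/O)c3ccccc3)n2-c2ccccc2)cc1` gives 63%; compound 2 `C=CCn1c(SC/C(=N/O)c2ccccc2)nnc1-c1ccc(OC)cc1` gives 66%; compound 3 `CCn1c(SC/C(=N/O)c2ccccc2)nnc1-c1ccc(OC)c(OC)c1` gives 67%.

The number for compound 3 is not separated from those of compound 2 or compound 1 by more than the usual scatter, so the three stand together. Among the measured compounds shown here, the only step measured between two compounds that differ in one place, a number 3 percentage points higher from compound 1 to compound 2 (within the scatter), concerns a different part of the molecule and offers no guide to the change at hand. Compound 4 `CCn1c(SC/C(=N/O)c2ccccc2)nnc1-c1ccc(OC)cc1` differs from compound 3 by hydrogen in place of methoxy on an aromatic carbon. For the measured compounds named here, no measured step bears on this removal, so the expectation rests on the closeness of the three numbers: for compound 4 a step of a number 3 percentage points lower from compound 3 to compound 4 (within the scatter) in this assay is expected, none beyond the scatter. Compound 4 is therefore estimated at 64%, within 54% to 74%.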

Compound 4, a percentage reported as inhibition, in the whole organism at one dose (the size of the read-out at that dose, not a potency): 72%
Compound 4: the middle estimate sits 8 percentage points below what was measured; the range from low to high includes it.
By their numbers in this assay, from the lowest: compounds 1, 2, 3 and 4 (each within the scatter of the next).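

In this assay, hydrogen in place of methoxy on the aromatic carbon gives a number 5 percentage points higher from compound 3 to compound 4 (within the scatter), so inhibition at this dose holds without this methoxy group. The group on the aromatic nitrogen also leaves the number within the scatter: methyl in place of vinyl on the chain gives a number 6 percentage points higher from compound 2 to compound 4 (within the scatter), and ethyl in place of phenyl gives a number 9 percentage points higher from compound 1 to compound 4 (within the scatter). Nothing available explains these numbers. Going by these compounds, it remains open whether a chlorine or a hydroxy group on that aromatic carbon, or a longer chain such as butyl on the aromatic nitrogen, would move the number beyond the scatter.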